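This account rests on a few compounds, and the source may have more. Where it says the series, first, only, none or still open, it means among the compounds named here.

Measured so far in a functional assay for inhibition, with Rattus norvegicus as the target; on this read-out lower numbers stand for stronger inhibition and higher numbers for weaker inhibition:

compound 1, `CCCCc1cc(OC)c2c(OC)cccc2c1OC(C)=O`: 260 nM
compound 2, `CCCCc1cc(OC)c2c(C)cccc2c1OC(C)=O`: 620 nM
compound 3, `CCc1c(CC)c(OC)c2c(OC)cccc2c1OC(C)=O`: 890 nM

Compound 4, `CCc1c(CC)c(OC)c2c(C)cccc2c1OC(C)=O`, is not yet measured. Its core is that of compound 3; how the core of compound 3 differs from that of compound 1 is not broken down here, beyond the two having the same atoms joined differently. Within the series the change made from compound 3 to compound 4 is methyl in place of methoxy on an aromatic carbon. The same change has been made once already, from compound 1 to compound 2, as methyl in place of methoxy on an aromatic carbon, and the two place lines agree word for word, so it is the same change. That step gave a 2.4-fold higher number from compound 1 to compound 2 (0.38 log units; beyond the scatter) in this assay. Among the compounds with values here, on that single precedent, a step of similar size is expected from compound 3 to compound 4, a 2.4-fold higher number from compound 3 to compound 4 (0.37 log units; beyond the scatter), with wider uncertainty because only one earlier instance a 2.4-fold higher number from compound 1 to compound 2 (0.38 log units; beyond the scatter) supports it. Compound 4 is therefore estimated at 2100 nM, with a range from 1000 nM to 4500 nM.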

Compound 4, half-maximal inhibitory concentration: 830 nM
The estimate for compound 4 lay 2.5-fold (0.40 log units) above the measured number; the measured number lies below the stated range.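

On the core of compound 3, methyl in place of methoxy on an aromatic carbon gives a 1.1-fold lower number from compound 3 to compound 4 (0.03 log units; within the scatter) in this assay. Set beside the earlier step on the core of compound 1, the two cannot be told apart: the same change on two cores in this assay, a 2.4-fold higher number (0.38 log units; beyond the scatter) from compound 1 to compound 2 and a 1.1-fold lower number (0.03 log units; within the scatter) from compound 3 to compound 4, 2.6-fold (0.41 log units) apart, within the scatter of two such steps. Within the data shown here, this gives no firm sign that the core alters the effect of the change, but it also does not show that the change carries over reliably, as only two pairs are available and only the step on the core of compound 1 lies beyond the scatter.

Still open, going by these compounds, is how a chlorine or a hydroxyl group on the same aromatic carbon would read. Also open, on these data alone, is whether the change behaves alike when an amide stands in place of the acetate ester.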